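From a Diethylamino Chain to a Hydroxy Chain

A few compounds are considered here, and "the series" means these few. Any claim that something is new, unique, unknown or untested is made for them only; others in the source may bear on it.

compound 1 `CCn1c(N)c(-c2nc3ccccc3[nH]2)c2nc(C#N)c(C#N)nc21`: > 50000 nM
compound 2 `CN(C)CCn1c(N)c(-c2nc3ccccc3[nH]2)c2nc(C#N)c(C#N)nc21`: 8880 nM
compound 3 `CCN(CC)CCn1c(N)c(-c2nc3ccccc3[nH]2)c2nc(C#N)c(C#N)nc21`: 11600 nM

These values come from a functional assay on HeLa cells (Homo sapiens) for antiproliferative activity, read by MTT assay, with a stated time of 48 h (on this read-out higher numbers stand for weaker inhibition and lower numbers for stronger inhibition), and the value for compound 1 is a limit of the assay. Compound 3 gives 11600 nM and has one close neighbour, with a 1.3-fold higher number from compound 2 to compound 3 (0.12 log units; within the scatter) so the dimethylamino and diethylamino chains cannot be told apart here.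

Compound 4 `N#Cc1nc2c(-c3nc4ccccc4[nH]3)c(N)n(CCO)c2nc1C#N` carries hydroxy in place of diethylamino on a saturated chain carbon, two bonds along the chain from an aromatic nitrogen and so keeps no amino group on its chain. Among the compounds with values here, two steps bear on this change, an at least 5.6-fold lower number from compound 1 to compound 2 (0.75 log units; beyond the scatter) and an at least 4.3-fold lower number from compound 1 to compound 3 (0.63 log units; beyond the scatter) and both are bounded by a limit. Within the data shown here, no measured step shows what hydroxy itself does. Read in reverse, they lead to the expectation of a move of similar size toward weaker inhibition, possibly ending at the limit. The expected move is a 3.0-fold higher number from compound 3 to compound 4 (0.48 log units; beyond the scatter) in this assay as estimated here. Compound 4 is expected at an estimated 35000 nM within a range of 14000 nM to 70000 nM for this measurement.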

Compound 4, half-maximal inhibitory concentration: > 50000 nM
Compound 4 ended at the assay's limit; the forecaster's own chance of this, stated with the estimate: 45%; middle value at least 1.4-fold (0.15 log units) from the limit.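

In this assay compound 4 gives > 50000 nM, which is a limit of the assay. Hydroxy on this saturated chain carbon therefore does not hold the activity of either amino chain, with an at least 4.3-fold higher number from compound 3 to compound 4 (0.63 log units; beyond the scatter) and an at least 5.6-fold higher number from compound 2 to compound 4 (0.75 log units; beyond the scatter), so among the compounds shown only the dimethylamino and diethylamino chains, in compound 2 and compound 3, give readable values. The step from compound 1 to compound 4 cannot be read, because both values are limits: the limit of > 50000 nM in this assay, at which 2 of the 4 values shown sit.

This leaves hydroxy and the plain ethyl chain of compound 1 unranked, so it is not known whether hydroxy does anything of its own at this place. The compounds shown also leave open whether a primary amine, a ring amine such as morpholine, or a longer chain ending in diethylamino would hold or improve the values of compound 2 and compound 3.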